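This account rests on a few compounds, and the source may have more. Where it says the series, first, only, none or still open, it means among the compounds named here.

Working notes on the series. Compound 1 `CCN(c1nc(Cl)nc(N[C@H](C)c2ccccc2)n1)C(C)C` stands highest of the three numbers in an ADME assay on the whole organism for inhibition, with Echinochloa crus-galli var. formosensis as the target, with a stated time of 4 days (on this read-out higher numbers stand for weaker inhibition and lower numbers for stronger inhibition), where compound 1 gives 52500 nM. Compound 2 `CCCN(CC)c1nc(Cl)nc(N[C@@H](C)c2ccccc2)n1` gives 282 nM and compound 3 `CCN(c1nc(Cl)nc(N[C@@H](C)c2ccccc2)n1)C(C)C` gives 229 nM. The one large move in the set is a 230-fold lower number from compound 1 to compound 3 (2.36 log units; beyond the scatter), and it rests on configuration alone, because of the fact that compounds 1 and 3 differ only in the configuration as drawn. By contrast a 1.2-fold lower number from compound 2 to compound 3 (0.09 log units; within the scatter) shows that trading propyl for isopropyl on the nitrogen on the aromatic ring leaves the number where it was.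

Compound 4 `CC(C)N(c1nc(Cl)nc(N[C@H](C)c2ccccc2)n1)C(C)C` differs from compound 1 by methyl in place of hydrogen on a saturated chain carbon bound to a nitrogen on an aromatic ring and a saturated chain carbon; the stereocentre drawn in compound 1 is kept unchanged in compound 4. The measured step that bears on this change is a 1.2-fold lower number from compound 2 to compound 3 (0.09 log units; within the scatter), within the scatter, while the large step of a 230-fold lower number from compound 1 to compound 3 (2.36 log units; beyond the scatter) does not apply, as the configuration is not touched. For compound 4 the expected step is therefore a 1.1-fold lower number from compound 1 to compound 4 (0.02 log units; within the scatter), with no move beyond the scatter in either direction. Compound 4 is thus estimated at 50000 nM, in the range 15000 nM to 160000 nM.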

Compound 4, half-maximal inhibitory concentration: 6610 nM
Beside the measured number, compound 4's estimate is 7.6-fold (0.88 log units) above it, outside the stated range (below it).
By their numbers in this assay, from the lowest: compounds 3 and 2 (each within the scatter of the next); then compound 4; then compound 1.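

In this assay, ethyl to isopropyl, which turns ethyl(isopropyl)amino into diisopropylamino, moves the number beyond the scatter with the stereocentre drawn R: a 7.9-fold lower number from compound 1 to compound 4 (0.90 log units; beyond the scatter). The substituents on this nitrogen therefore do not always leave the number where it was, although the earlier step at this nitrogen, a 1.2-fold lower number from compound 2 to compound 3 (0.09 log units; within the scatter), stayed within the scatter; that step has the stereocentre drawn S and is a different change, propyl to isopropyl. Nothing at hand gives a cause for the step from ethyl to isopropyl.

Going by these compounds, whether diisopropylamino would also lower the number with the stereocentre drawn S remains open. Also open, on these data alone, is how a tert-butyl group or a methoxyethyl chain on the same nitrogen would read in this assay.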